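A few compounds are considered here, and "the series" means these few. Any claim that something is new, unique, unknown or untested is made for them only; others in the source may bear on it.

- Compound 1 `COc1cc(CCc2ccccn2)cc(OC)c1O`: > 25000 nM (a limit)
- Compound 2 `COc1cc(CCc2ccncc2)cc(OC)c1O`: 6300 nM

Among the measured compounds shown here, in a functional assay on MDA-MB-231 cells (Homo sapiens) for antiproliferative activity, read by MTT assay, with a stated time of 72 h (on this read-out higher numbers stand for weaker inhibition and lower numbers for stronger inhibition), compound 2 gives 6300 nM, the only actual number so far. Compound 1 gives > 25000 nM, which is a limit of the assay and not a number.

Compound 3 `COc1cc(CCc2ccccc2)cc(OC)c1O` has not been measured. It differs from compound 2 as follows: phenyl in place of pyridin-4-yl on a saturated chain carbon, two bonds along the chain from an aromatic carbon. In words, this is phenyl in place of pyridin-4-yl on a saturated chain carbon, two bonds along the chain from an aromatic carbon.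

For the measured compounds named here, one measured step bears on this: an at least 3.9-fold lower number from compound 1 to compound 2 (0.59 log units; beyond the scatter). Going by the values given here, it shows that exchanging the ring on this chain can shift the number, but it compares two pyridinyl groups, and no phenyl compound has a value yet. No step beyond the scatter is therefore expected, though the uncertainty is wide. The expected change is a 1.4-fold higher number from compound 2 to compound 3 (0.15 log units; within the scatter). In this assay the estimated value for compound 3 is 9000 nM, with an expected range from 3000 nM to 25000 nM.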

Compound 3, half-maximal inhibitory concentration: > 25000 nM
Compound 3 was reported as a limit; the forecaster's own chance of this, stated with the estimate: 25%; at least 2.7-fold (0.44 log units) between middle value and limit.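

In this assay, phenyl in place of pyridin-4-yl gives an at least 3.9-fold higher number from compound 2 to compound 3 (0.59 log units; beyond the scatter), so a ring of carbon only does not keep the activity of compound 2, even though both rings have the same number of heavy atoms. The ring nitrogen alone does not account for the value either, since compound 1 also carries one in its pyridin-2-yl group and gives no actual number, which leaves pyridin-4-yl as the only ring shown with a measured value. Compound 1 and compound 3 cannot be compared because both sit at one limit, which is not a number: the limit of > 25000 nM in this assay, at which 2 of the 3 values shown sit.

From the compounds shown here alone, how far either compound lies past that limit remains unknown. Also open, going by these compounds, is whether pyridin-3-yl on the same chain, or a longer chain carrying pyridin-4-yl, would match or improve on compound 2.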